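This account rests on a few compounds, and the source may have more. Where it says the series, first, only, none or still open, it means among the compounds named here.

Compound 1 `CN(c1ccncc1)n1cccc1Cl` and compound 2 `CC(O)c1cccn1N(C)c1ccncc1` both lie outside the measurable range of a functional assay on the whole organism with Mus musculus as the target; on this read-out lower numbers stand for an effect already at smaller amounts and higher numbers for an effect only at larger amounts of compound. In this assay compound 1 returns only the limit > 20 mg/kg. Compound 2 likewise returns only the limit > 20 mg/kg. Among the compounds with values here, the step that the two limits leave unreadable from compound 1 to compound 2 therefore cannot be sized, and the sole evidence is the limit of > 20 mg/kg in this assay, at which 2 of the 2 values shown sit. Compound 3 `CN(c1ccncc1)n1cccc1C#N` differs from compound 2 by cyano in place of 1-hydroxyethyl on an aromatic carbon. No measured step sizes a change of this kind. For compound 3 the dose in this assay is expected near 25 mg/kg, within 8 mg/kg to 80 mg/kg. The expected step that the limit leaves unreadable from compound 2 to compound 3 would thus stay within the scatter, most likely reported again as a limit.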

Compound 3, dose for half-maximal effect: > 20 mg/kg
Compound 3 ended at the assay's limit; the forecaster's own chance of this, stated with the estimate: 70%; the middle value is on the limit's open side.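

In this assay, within the data shown here, compound 1, compound 2 and compound 3 all stand at a limit, so no step among them can be read. Still open, from the compounds shown here alone, is whether chloro, 1-hydroxyethyl and cyano differ at all on this read-out.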